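The compounds below may be only part of what the source reports. "The series", "measured", "known", "first", "only" and "open" are said of these compounds alone.

Of the compounds shown here, three have so far been tested in an assay on isolated protein for inhibition of Alpha glucosidase (Homo sapiens), with stated times of 5 min and 15 min, tested at 50 uM; on this read-out lower numbers stand for less inhibition and higher numbers for more inhibition at the one concentration tested (going by the name of the read-out). Compound 1 `O=C1/C(=C/c2ccccc2)CCC/C1=C\c1ccc(Cl)cc1` gives 27.6%, compound 2 `COc1ccc(/C=C2\CCC/C(=C\c3ccccc3)C2=O)cc1` gives 31.4%, and compound 3 `O=C(/C=C(O)/C=C/c1cc(O)ccc1O)c1cc(O)ccc1O` gives 96.9%. On these numbers compound 2 sits close to compound 1, the two values lying within the scatter of each other, while compound 3 stands far above both, a gap well beyond the scatter.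

Compound 4 `Cc1ccc(/C=C2\CCC/C(=C\c3ccccc3)C2=O)cc1` differs from compound 2 in one place: methyl in place of methoxy on an aromatic carbon. Among the measured compounds shown here, the one measured step that bears on this, a swap of the group on the same aromatic carbon, went a number 3.8 percentage points higher from compound 1 to compound 2 (within the scatter), so a change at that position left the reading essentially unmoved. A methyl in place of methoxy at the same spot is therefore expected to produce no step beyond the scatter in this assay. For compound 4 the expected step is a number 1.4 percentage points lower from compound 2 to compound 4 (within the scatter), and the estimate for compound 4 is 30%, with a range from 15% to 45%.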

Compound 4, a percentage reported as inhibition, at one concentration (the size of the read-out at that concentration, not a potency): 34.1%
Compound 4: middle estimate off by 4.1 percentage points, on the low side, within the range that was stated.
By their numbers in this assay, from the lowest: compounds 1, 2 and 4 (each within the scatter of the next); then compound 3.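

In this assay, methyl on the aromatic carbon para to a large group gives a number 2.7 percentage points higher from compound 2 to compound 4 (within the scatter) when it replaces methoxy, and a number 6.5 percentage points higher from compound 1 to compound 4 (within the scatter) when it replaces chloro, so three different groups at this position now give readings within the scatter of one another. Methoxy carries one hydrogen-bond acceptor and methyl none, yet this difference comes with no step beyond the scatter, so an acceptor at this position is not needed to reach the level of compound 2. No measurement available here explains why these readings stay so close.

On these data alone, it remains open whether a group of another kind at this position, such as an amine or a carboxylic acid, would move the reading beyond the scatter. As far as these compounds go, the other aromatic ring of the shared core, which carries no added group in compounds 1, 2 and 4, also remains untested by these comparisons.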